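The source may report more compounds than this note shows. Statements on the series, on what has been measured and on what is new or still open speak of the compounds shown alone.

Working notes on the series. Compound 1 `COc1ccc(-n2c(SCC(=O)c3ccccc3)nnc2-c2cc(OC)c(OC)c(OC)c2)cc1` carries a benzoylmethylsulfanyl group. In a functional assay on PC-3 cells (Homo sapiens) for inhibition, read by MTT assay, with a stated time of 48 h (a higher number here means a weaker inhibitor, a lower number a stronger inhibitor), compound 1 reports only a limit, > 60000 nM. Within the data shown here, compound 2 `CCSc1nnc(-c2cc(OC)c(OC)c(OC)c2)n1-c1ccc(N(C)C)cc1`, with an ethylsulfanyl group, holds the only actual number: in this assay compound 2 gives 46200 nM. The other value shown is a limit, (the limit of > 60000 nM in this assay, at which 1 of the 2 values shown sits). Compound 3 `COc1cc(-c2nnc(SCC(=O)c3ccccc3)n2-c2ccc(N(C)C)cc2)cc(OC)c1OC` is not yet measured; it differs from compound 2 by benzoyl in place of methyl on a saturated chain carbon bound to a sulfur. Among the measured compounds shown here, no measured pair shows this change on its own. The step to compound 3 is expected to be a 1.1-fold higher number from compound 2 to compound 3 (0.03 log units; within the scatter), no larger than the scatter. The estimate for compound 3 is 50000 nM, range 15000 nM to 150000 nM.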

Compound 3, half-maximal inhibitory concentration: 38600 nM
Compound 3: middle estimate off by 1.3-fold (0.11 log units), on the high side; the measured number falls inside the stated range.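

In this assay benzoyl in place of methyl on a saturated chain carbon bound to a sulfur gives a 1.2-fold lower number from compound 2 to compound 3 (0.08 log units; within the scatter) with the dimethylamino group held, so this position tolerates the larger group with no readable change. Dimethylamino in place of methoxy on an aromatic carbon gives an at least 1.5-fold lower number from compound 1 to compound 3 (0.19 log units; that floor lies within the scatter) with the benzoylmethylsulfanyl group held. That step is only a floor, since one end of it is a limit: the limit of > 60000 nM in this assay, at which 1 of the 3 values shown sits.

On these data alone, whether an amine or a carboxylic acid in place of benzoyl on that chain would move the number beyond the scatter stays open.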